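Anilide acyl variants of an iodophenyl sulfonate series

The source may hold more compounds than are shown below. What is called first, only, known or untested is meant among the compounds shown, and "the series" means these compounds.

Measured compounds, with their values in a functional assay on HT-29 cells (Homo sapiens) for antiproliferative activity, read by sulforhodamine B assay, with a stated time of 48 h; on this read-out lower numbers stand for stronger inhibition and higher numbers for weaker inhibition:

compound 1 `CC(=O)Nc1ccc(S(=O)(=O)Oc2ccccc2I)cc1` gives 23000 nM
compound 2 `CC(C)(C)C(=O)Nc1ccc(S(=O)(=O)Oc2ccccc2I)cc1` gives 9500 nM
compound 3 `O=C(CCCl)Nc1ccc(S(=O)(=O)Oc2ccccc2I)cc1` gives 14000 nM

Compound 3 stands second highest of the three numbers. Its steps to the other two, a 1.6-fold lower number from compound 1 to compound 3 (0.22 log units; within the scatter) and a 1.5-fold higher number from compound 2 to compound 3 (0.17 log units; within the scatter), both lie within the scatter, so nothing separates it from either neighbour with confidence. Among the measured compounds shown here, the only step among the measured compounds that exceeds the scatter is a 2.4-fold lower number from compound 1 to compound 2 (0.38 log units; beyond the scatter), and that too is modest.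

Compound 4 `CCNC(=O)Nc1ccc(S(=O)(=O)Oc2ccccc2I)cc1` differs from compound 3 by ethylamino in place of 2-chloroethyl on a carbonyl carbon. For the measured compounds named here, no measured step exchanges a carbon chain on that carbonyl carbon for a nitrogen-bearing group; the three measured steps only exchange one carbon group for another at the same place, and together they span a narrow range of numbers. On that basis the change from compound 3 to compound 4 is expected to stay within the scatter, with a 1.1-fold higher number from compound 3 to compound 4 (0.03 log units; within the scatter) as the estimated step. Compound 4 is therefore expected to give about 15000 nM in this assay, within a range of 5000 nM to 45000 nM.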

Compound 4, half-maximal inhibitory concentration: 5300 nM
Estimate against measurement, compound 4: 2.8-fold (0.45 log units) above, within the range that was stated.
By their numbers in this assay, from the lowest: compounds 4, 2, 3 and 1 (each within the scatter of the next, the first and the last beyond it).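

At this carbonyl carbon a nitrogen-bearing group is accepted in this assay, and swapping 2-chloroethyl for ethylamino, with the same count of heavy atoms and one added hydrogen-bond donor, gives a step beyond the scatter: a 2.6-fold lower number from compound 3 to compound 4 (0.42 log units; beyond the scatter). Against methyl the step is also beyond the scatter, though modest, at a 4.3-fold lower number from compound 1 to compound 4 (0.64 log units; beyond the scatter), whereas a 1.8-fold lower number from compound 2 to compound 4 (0.25 log units; within the scatter) stays within it, so ethylamino and tert-butyl cannot be told apart at this place. Nothing available gives a reason for these steps.

Open, on these data alone, is whether the entering nitrogen or the departing chlorine accounts for the step from compound 3 to compound 4; a plain propyl group at this carbonyl carbon would separate the two. Also open, as far as these compounds go, is how a longer chain on that nitrogen, or a dimethylamino group without the hydrogen-bond donor, would read in this assay.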